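The compounds below may be only part of what the source reports. "The series", "measured", "known", "first", "only" and "open" are said of these compounds alone.

In an ADME assay on HepG2 cells (Homo sapiens) for cytotoxicity, read by MTT assay, with a stated time of 48 h (on this read-out lower numbers stand for stronger inhibition and higher numbers for weaker inhibition), compound 1 (`O=S(=O)(c1ccc(-c2ccc3ncnc(Nc4ccc(OCc5cccc(F)c5)c(Cl)c4)c3c2)cc1)N1CCCCC1`) gives > 15000 nM, which is a limit and not a number. Compound 2 (`Cc1ccc(Nc2ncnc3ccc(-c4ccc(S(=O)(=O)N5CCOCC5)cc4)cc23)cc1`) gives > 15000 nM, which is also a limit. Neither compound has an exact number, and the position of compound 2 is the limit of > 15000 nM in this assay, at which 2 of the 2 values shown sit.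

For the measured compounds named here, compound 3 (`COc1ccc(Nc2ncnc3ccc(-c4ccc(S(=O)(=O)N5CCOCC5)cc4)cc23)cc1Cl`) carries 3-chloro-4-methoxyphenyl in place of 4-methylphenyl on a nitrogen on an aromatic ring, and this is its only difference from compound 2: 3-chloro-4-methoxyphenyl in place of 4-methylphenyl on a nitrogen on an aromatic ring. Going by the values given here, no pair of measured compounds shows what such a swap does, so the only guide is the limit held by compound 2.

The estimated step that the limit leaves unreadable from compound 2 to compound 3 in this assay is expected to stay within the usual scatter, with no clear direction. For compound 3 the expected value is 20000 nM, with an estimated range from 10000 nM to 40000 nM, and the read-out may well be only a limit again.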

Compound 3, half-maximal inhibitory concentration: > 15000 nM
Compound 3: a limit, no number (the forecaster's own chance of this, stated with the estimate: 70%); the middle value is on the limit's open side.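

For the compounds shown here, compound 2 and compound 3 both sit at a limit and not at a number, so no step between them can be read: the limit of > 15000 nM in this assay, at which 3 of the 3 values shown sit.

The compounds shown leave open whether any of them has a measurable effect in this assay and whether 3-chloro-4-methoxyphenyl differs from 4-methylphenyl there.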